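A few compounds are considered here, and "the series" means these few. Any claim that something is new, unique, unknown or untested is made for them only; others in the source may bear on it.

Of the compounds shown here, three have been measured in an assay on HEK293 cells for binding affinity to 5-hydroxytryptamine receptor 7 (Homo sapiens), read by radioligand binding, tested at 1 uM; on this read-out higher numbers stand for more inhibition at the one concentration tested (going by the name of the read-out) and lower numbers for less inhibition. Compound 1 `Brc1ccc2ccn(CCN3CCN(C4CCCCC4)CC3)c2c1` gives 36% in this assay. Compound 2 `CN1CCCN(CCn2ccc3cccc(Br)c32)CC1` gives 18% in this assay. Compound 3 `CN1CCCN(CCn2ccc3ccc(C(N)=O)cc32)CC1` gives 33% in this assay. Among these three numbers, compound 3 stands second highest: its number and that of compound 1 lie within the usual scatter of each other, so nothing separates the two, whereas its number lies above that of compound 2 by a gap that goes beyond the scatter.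

Compound 4 `CN1CCCN(CCn2ccc3ccc(-c4cccnc4)cc32)CC1` has not yet been measured. It differs from compound 3 in one place: pyridin-3-yl in place of carbamoyl on an aromatic carbon. Going by the values given here, no pair of measured compounds that differ in one place is available, so no measured step can guide the size of this change. The expectation rests on compound 3 alone, whose value of 33% sits in the middle of the small range seen so far. Compound 4 is expected to give about 42% in this assay, with a range from 18% to 66%. The step this estimate means, a number 9 percentage points higher from compound 3 to compound 4 (within the scatter), is expected to be a modest rise that may not clearly exceed the scatter.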

Compound 4, a percentage reported as inhibition, at one concentration (the size of the read-out at that concentration, not a potency): 35%
Compound 4: middle estimate off by 7 percentage points, on the high side, within the range that was stated.
By their numbers in this assay, from the lowest: compound 2; then compounds 3, 4 and 1 (each within the scatter of the next).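

In this assay, going by these compounds alone, the first step between compounds that differ in one place, a number 2 percentage points higher from compound 3 to compound 4 (within the scatter), lies within the scatter; it replaces carbamoyl with pyridin-3-yl on the aromatic carbon that is meta to a fused ring and para to a fused ring. At this place, then, a group of 3 heavy atoms with no ring and 1 hydrogen-bond donor gives way to one of 6 heavy atoms with a six-membered aromatic ring and 0 hydrogen-bond donors, and the read-out shows no difference that can be told from scatter. Nothing at hand explains why the two numbers stay so close.

The compounds shown leave open whether this place would stay as flat with a different kind of group, such as a carboxylic acid or a primary amine on the same aromatic carbon. Within the data shown here, they also leave open whether the same exchange would give a similar step on the core of compound 1, since this one pair is the only measured comparison at this position.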